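This account rests on a few compounds, and the source may have more. Where it says the series, first, only, none or still open, it means among the compounds named here.

Measured so far in an assay (Rattus norvegicus) for inhibition of Fatty-acid amide hydrolase 1 (Homo sapiens); on this read-out higher numbers stand for weaker inhibition and lower numbers for stronger inhibition: compound 1 `O=C(CCCCCCc1ccccc1)c1ncc(-c2ncccn2)o1` gives 5.3 nM; compound 2 `CN(C)C(=O)c1cnc(C(=O)CCCCCCc2ccccc2)o1` gives 2 nM; compound 3 `O=C(CCCCCCc1ccccc1)c1ncc(I)o1` gives 3 nM.

Compound 3 stands second highest of the three numbers; its gap to compound 2 is within the scatter, and so is its gap to compound 1, so the three compounds cannot be ordered on this read-out.

Compound 4 `O=C(CCCCCCc1ccccc1)c1ncc(-c2cc(=O)[nH]c(=O)[nH]2)o1` is the next member. The change from compound 3 is a group of 8 heavy atoms (4 carbon, 2 nitrogen, 2 oxygen; one six-membered aromatic ring with 2 hetero atoms) in place of one iodine atom, on an aromatic carbon, the entering group carrying two hydrogen-bond donors and two acceptors where the iodine carried none.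

Going by the values given here, two measured steps bear on it, both exchanges at the same aromatic carbon. The step of a 1.8-fold lower number from compound 1 to compound 3 (0.25 log units; within the scatter) shows that a six-membered aromatic ring with two hetero atoms and a single iodine atom give numbers within the scatter of each other. The step of a 1.5-fold higher number from compound 2 to compound 3 (0.18 log units; within the scatter) shows the same for dimethylcarbamoyl against iodine. The substituent at this carbon has so far moved this assay by no more than the scatter, and the entering group of compound 4 is again a six-membered aromatic ring with two hetero atoms. Among the compounds with values here, no measured compound carries hydrogen-bond donors at this carbon, so that part of the change is untested.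

The expectation for compound 4 is therefore a step of a 1.7-fold higher number from compound 3 to compound 4 (0.22 log units; within the scatter), no change beyond the scatter. Compound 4 is estimated at 5 nM in this assay, within the range 1.5 nM to 20 nM.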

Compound 4, inhibition constant: 12 nM
The estimate for compound 4 lay 2.4-fold (0.38 log units) below the measured number, within the range that was stated.
By their numbers in this assay, from the lowest: compounds 2, 3 and 1 (each within the scatter of the next, the first and the last beyond it); then compound 4.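

In this assay the substituent on the aromatic carbon next to the ring oxygen now moves the number beyond the scatter relative to iodo, with a 4.0-fold higher number from compound 3 to compound 4 (0.60 log units; beyond the scatter), whereas the exchanges of iodo against pyrimidin-2-yl and dimethylcarbamoyl stayed within it, and the gap to the dimethylcarbamoyl compound is larger still at a 6.0-fold higher number from compound 2 to compound 4 (0.78 log units; beyond the scatter). A six-membered aromatic ring with two hetero atoms is also not interchangeable with another of that description at this carbon: pyrimidin-2-yl and the entering ring, which adds hydrogen-bond donors and double bonds outside aromatic rings, are separated by a 2.3-fold higher number from compound 1 to compound 4 (0.35 log units; beyond the scatter), so the ring type as counted does not by itself set the number, though all three steps remain modest. Nothing measured on these compounds accounts for the loss.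

The compounds shown do not separate the contribution of the hydrogen-bond donors from that of the carbonyl groups of the entering ring. As far as these compounds go, a pyrimidin-2-yl ring carrying an amine, or a carboxylic acid on the same carbon, would bear on that question, and how far either would follow compound 4 remains open.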